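A few compounds are considered here, and "the series" means these few. Any claim that something is new, unique, unknown or untested is made for them only; others in the source may bear on it.

Measured so far:
compound 1 `ONc1ccc(CNc2cc(Br)cc3[nH]ncc23)cc1`: "not active" (no number reported)
compound 2 `N#Cc1ccc(CNc2cc(Br)cc3[nH]ncc23)cc1`: 70%

Among the compounds with values here, in an assay for inhibition of Indoleamine 2,3-dioxygenase 1 (Homo sapiens), with a stated time of 1 h, tested at 10 uM (on this read-out higher numbers stand for more inhibition at the one concentration tested (going by the name of the read-out) and lower numbers for less inhibition), compound 2 gives 70%, the only number in the set; compound 1 is recorded in this assay as "not active" (no number reported), without a number. Compound 3 `NS(=O)(=O)c1ccc(CNc2cc(Br)cc3[nH]ncc23)cc1` differs from compound 2 by sulfamoyl in place of cyano on an aromatic carbon. Within the data shown here, no step between measured compounds is available, so the size of this change has no anchor in the set. The expected step in this assay is a number 25 percentage points lower from compound 2 to compound 3 (beyond the scatter), downward and beyond the usual scatter. Compound 3 is estimated at 45% in this assay, within 15% to 75%.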

Compound 3, a percentage reported as inhibition, at one concentration (the size of the read-out at that concentration, not a potency): 20%
Beside the measured number, compound 3's estimate is 25 percentage points above it; the measured number falls inside the stated range.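

In this assay, within the data shown here, there is a number 50 percentage points lower from compound 2 to compound 3 (beyond the scatter) with sulfamoyl in place of cyano on an aromatic carbon, para to a large group, the first measured step at this position. Compound 3 at 20% still has a number, while compound 1 stands as "not active" (no number reported) without one. No available measurement bears on the reason for this step.

Open, on these data alone, is whether a carboxylic acid or a primary amide at this place would read nearer compound 2 or compound 3. Also open, as far as these compounds go, is whether the step would hold with another group in place of the bromine on the shared core.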